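The source may hold more compounds than are shown below. What is called first, only, known or untested is meant among the compounds shown, and "the series" means these compounds.

Compounds measured so far:
- compound 1, `CO[C@H]1C(=O)N2C(C(=O)c3ccccc3)=C(C)CS(=O)(=O)[C@H]12`: 33 h
- compound 2, `CO[C@H]1C(=O)N2C(C(=O)C(C)(C)C)=C(CSc3nnnn3C)C(Sc3nnnn3C)S(=O)(=O)[C@H]12`: 24 h
- compound 3, `CO[C@H]1C(=O)N2C(C(=O)c3ccccc3)=C(CSc3nnnn3C)C(Sc3nnnn3C)S(=O)(=O)[C@H]12`: 850 h

In a physicochemical assay for pharmacokinetics, at 37 degrees C (a lower number here means that the compound disappears faster, a higher number that the compound lasts longer), compound 3 gives the highest of the three numbers. Among the compounds with values here, the only single-point step measured is a 35-fold higher number from compound 2 to compound 3 (1.55 log units; beyond the scatter), which swaps the group on the carbonyl carbon. Within the data shown here, compound 1 and compound 3 differ in two places at once, so no single step links them; their values simply show that compound 1 lasts far less long than compound 3.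

Compound 4, `CO[C@H]1C(=O)N2C(C(=O)c3ccccc3)=C(CSc3nnnn3C)CS(=O)(=O)[C@H]12`, comes from compound 3 by one change: hydrogen in place of (1-methyl-1H-tetrazol-5-yl)sulfanyl on a saturated ring carbon. Among the measured compounds shown here, no measured step removes this group from the ring carbon, so the expected size of the change in this assay cannot be read from any step directly. Compound 1, which carries neither of the two tetrazole groups, sits far lower than compound 3, and compound 4 keeps one of them, so its number is expected to fall between those two. The step of a 7.1-fold lower number from compound 3 to compound 4 (0.85 log units; beyond the scatter) is therefore estimated to be downward, and beyond the scatter. For compound 4 the estimate in this assay is 120 h, with a range from 30 h to 500 h.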

Compound 4, half-life: 8.6 h
Beside the measured number, compound 4's estimate is 14-fold (1.14 log units) above it; the whole stated range lies above it.
By their numbers in this assay, from the lowest: compound 4; then compounds 2 and 1 (each within the scatter of the next); then compound 3.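

In this assay putting hydrogen in place of (1-methyl-1H-tetrazol-5-yl)sulfanyl on the saturated ring carbon next to the ring sulfur gives a 99-fold lower number from compound 3 to compound 4 (1.99 log units; beyond the scatter) and this large drop shows that the long life of compound 3 depends heavily on what sits at this one ring position. The same group behaves differently elsewhere: with hydrogen on that ring carbon, (1-methyl-1H-tetrazol-5-yl)sulfanyl in place of hydrogen on the saturated chain carbon bound to a double-bonded ring carbon gives a 3.8-fold lower number from compound 1 to compound 4 (0.58 log units; beyond the scatter) and so, in these compounds, the group lowers the number at the chain site but raises it at the ring site. No measured evidence here explains this difference between the two sites.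

The compounds shown leave open whether the high number needs the tetrazole ring itself, or whether a simpler group on that ring carbon, such as methylsulfanyl or methoxy, would give a similar result. They also leave open whether the ring-carbon step would be as large with tert-butyl on the carbonyl in place of phenyl.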